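The source may hold more compounds than are shown below. What is called first, only, known or untested is meant among the compounds shown, and "the series" means these compounds.

Compound 1, `CC(C)c1onc(-c2c(Cl)cccc2Cl)c1COc1ccc(C2CC2(C#N)c2ccc(C(=O)O)cc2)c(Cl)c1`: in an assay on HEK293T cells for agonist activity at Bile acid receptor (Homo sapiens), read by TR-FRET and LanthaScreen (a higher number here means that more compound is needed for the effect, a lower number that less compound is needed), compound 1 gives < 100 nM, which is a limit of the assay rather than a number.
Compound 2, `CCc1onc(-c2c(Cl)cccc2Cl)c1COc1ccc(C2(C#N)CC2c2ccc(C(=O)O)cc2)c(Cl)c1`: in this assay compound 2 gives < 100 nM, again a limit and not a number.

Compound 2 thus stands at the limit, as does the other measured compound: the limit of < 100 nM in this assay, at which 2 of the 2 values shown sit. On the numbers shown nothing separates compound 2 from compound 1. For the measured compounds named here, no step between measured compounds that differ in a single place is available.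

Compound 3, `CCc1onc(-c2c(Cl)cccc2Cl)c1COc1ccc(C2(C)CC2c2ccc(C(=O)O)cc2)c(Cl)c1`, differs from compound 2 by methyl in place of cyano on a saturated ring carbon. Since both measured values sit as limits, the size of this step cannot be read from the measured compounds. A step of modest size in this assay is expected, somewhat more likely toward more compound being needed than toward less, though a step within the usual scatter would not be surprising. Compound 3 is therefore estimated at 80 nM in this assay, with a range from 15 nM to 400 nM, which corresponds to an expected step that the limit leaves unreadable from compound 2 to compound 3.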

Compound 3, half-maximal effective concentration: < 100 nM
Compound 3 gave a limit, no number; the forecaster's own chance of this, stated with the estimate: 50%; the middle value does not contradict the limit.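

In this assay compound 3 gives < 100 nM and this is a limit of the assay, not a number. For the compounds shown here, no step from compound 2 to compound 3 can be read: the limit of < 100 nM in this assay, at which 3 of the 3 values shown sit. The compounds shown leave open whether methyl in place of cyano on a saturated ring carbon changes how much compound is needed, and by how much.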